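This account rests on a few compounds, and the source may have more. Where it says the series, first, only, none or still open, it means among the compounds named here.

Measured in a functional assay on A549 cells (Homo sapiens) for inhibition, read by MTT assay, with a stated time of 48 h; on this read-out lower numbers stand for stronger inhibition and higher numbers for weaker inhibition:
- Compound 1 `C[Se]c1ccc(N(C)c2nc(C3CC3)nc3ccccc23)cc1`: 13 nM
- Compound 2 `COc1ccc(N(C)c2nc(C)nc3ccccc23)cc1[Se]C`: 11 nM
- Compound 3 `Cc1nc(N(C)c2ccc([Se]C#N)c(Cl)c2)c2ccccc2n1`: 7 nM

These three numbers sit close together. Compound 1 and compound 3 both lie within the usual scatter of compound 2, which gives 11 nM, so compound 2 cannot be separated from either.

Compound 4 `COc1ccc(N(C)c2nc(C)nc3ccccc23)cc1C[Se]C#N` has not yet been measured in this assay. Its change from compound 2 is this: a group of 4 heavy atoms (2 carbon, 1 nitrogen, 1 selenium; no ring) in place of a group of 2 heavy atoms (1 carbon, 1 selenium; no ring), on an aromatic carbon. The change sits on an aromatic carbon, ortho to a methoxy group, and brings in a triple bond outside aromatic rings.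

For the measured compounds named here, no measured pair differs in one place only, so the data show no direct size for such a step. Compound 3 also carries selenium in a group with a triple bond, and compound 3 gives 7 nM. A step beyond the scatter is therefore not expected, in either direction.

The estimated change is a 1.4-fold higher number from compound 2 to compound 4 (0.13 log units; within the scatter). For compound 4 the expected value is 15 nM, with an estimated range of 4 nM to 80 nM.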

Compound 4, half-maximal inhibitory concentration: 98 nM
Beside the measured number, compound 4's estimate is 6.5-fold (0.82 log units) below it, outside the stated range (above it).
By their numbers in this assay, from the lowest: compounds 3, 2 and 1 (each within the scatter of the next); then compound 4.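

In this assay this aromatic carbon, ortho to a methoxy group, proves sensitive to what it carries: the group of 4 heavy atoms in place of the group of 2 heavy atoms gives an 8.9-fold higher number from compound 2 to compound 4 (0.95 log units; beyond the scatter), the first direct size for a single change in this set. Both groups contain selenium, so having selenium at this position does not by itself keep the number low. No available evidence accounts for this result.

The compounds shown leave open whether the higher number goes with the larger group or with its triple bond. A longer chain or an amine at this position would help to separate these possibilities and show how much change this position tolerates.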